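The source may hold more compounds than are shown below. What is called first, only, known or untested is meant among the compounds shown, and "the series" means these compounds.

Measured so far in a functional assay on DWD cells (Homo sapiens) for inhibition, read by sulforhodamine B assay; on this read-out higher numbers stand for weaker inhibition of growth and lower numbers for stronger inhibition of growth:
- compound 1 `COc1ccc(-c2ccc(-c3ccc(-c4nc5cc(C)ccc5[nH]4)cc3)cc2)cc1OC` gives 1720 nM
- compound 2 `COc1cc(-c2ccc(-c3ccc(-c4nc5cc(C)ccc5[nH]4)cc3)cc2)cc(OC)c1OC` gives 170 nM
- compound 3 `FC(F)(F)c1ccc(-c2ccc(-c3ccc(-c4nc5ccccc5[nH]4)cc3)cc2)cc1` gives 100000 nM

Compound 2 has the lowest number of the three, with compound 1 the nearer of the other two and compound 3 far higher. Compound 4 `COc1cc(-c2ccc(-c3ccc(-c4nc5c(O)cccc5[nH]4)cc3)cc2)cc(OC)c1OC` has not yet been measured in this assay and differs from compound 2 in one place: 4-hydroxy-1H-benzimidazol-2-yl in place of 5-methyl-1H-benzimidazol-2-yl on an aromatic carbon. This places 4-hydroxy-1H-benzimidazol-2-yl where 5-methyl-1H-benzimidazol-2-yl stood.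

For the measured compounds named here, the only measured step between close neighbours is a 10-fold lower number from compound 1 to compound 2 (1.01 log units; beyond the scatter), with methoxy in place of hydrogen on an aromatic carbon. It is large and shows that one change can move this read-out strongly, but it concerns a methoxy group that compound 2 and compound 4 share. Compound 3 differs from compound 2 in more than one place, so it does not isolate the change either. Going by the values given here, no measured pair tests this replacement, and the data therefore support no firm direction. No shift beyond the scatter is expected, though with low confidence, and the estimated step is a 1.5-fold higher number from compound 2 to compound 4 (0.17 log units; within the scatter) in this case. For compound 4 the estimated value is 250 nM with an expected range from 40 nM to 1500 nM as wide bounds.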

Compound 4, concentration for 50% growth inhibition: 190 nM
For compound 4 the middle estimate is 1.3-fold (0.12 log units) above the measured one; the range from low to high includes it.
By their numbers in this assay, from the lowest: compounds 2 and 4 (each within the scatter of the next); then compound 1; then compound 3.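

In this assay, for the compounds shown here, 4-hydroxy-1H-benzimidazol-2-yl in place of 5-methyl-1H-benzimidazol-2-yl gives a 1.1-fold higher number from compound 2 to compound 4 (0.05 log units; within the scatter), the first reading on this group, since the only earlier step between close neighbours concerned a methoxy group. The group therefore accepts this exchange with no shift beyond the scatter, even though the substituent changes from methyl to hydroxy, its number within the group changes, and the hydrogen-bond donor and acceptor counts differ between the two groups. Nothing available explains why the two groups read alike.

Open, going by these compounds, is whether an amine or a carboxylic acid in place of the hydroxy would stay within the scatter of compound 4, and whether the substituent and its number on the group matter separately, as this single exchange alters both together. Also open, on these data alone, is whether the same exchange would read alike on the core of compound 1, which gives 1720 nM, so the present finding holds only for the core shared by compound 2 and compound 4.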